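The source may report more compounds than this note shows. Statements on the series, on what has been measured and on what is new or still open speak of the compounds shown alone.

Measured compounds in an ADME assay on HEK293-A cells (Homo sapiens) for cytotoxicity, read by MTT assay, with a stated time of 48 h; on this read-out higher numbers stand for weaker inhibition and lower numbers for stronger inhibition:
- compound 1, `CCN1CCN(C[C@H]2CN(c3ccc(-n4cc(-c5ccccn5)cn4)c(F)c3)C(=O)O2)CC1`: 99 ug/mL
- compound 2, `COC(=O)CC1CCN(C[C@H]2CN(c3ccc(-n4cc(-c5ccccn5)cn4)c(F)c3)C(=O)O2)CC1`: 224 ug/mL
- compound 3, `O=C1O[C@@H](CSc2cccs2)CN1c1ccc(-n2cc(-c3ccccn3)cn2)c(F)c1`: a limit only, > 400 ug/mL

Compound 1 sits lowest of the three numbers. Compound 2 lies higher, with a 2.3-fold higher number from compound 1 to compound 2 (0.35 log units; beyond the scatter). For compound 3 the read-out is a limit and not a number; it is one of the values caught by the limit of > 400 ug/mL in this assay, at which 1 of the 3 values shown sits. Compound 3 therefore stands at the top of the shown range, reached by an at least 4.0-fold higher number from compound 1 to compound 3 (0.60 log units; beyond the scatter) from compound 1, while an at least 1.7-fold higher number from compound 2 to compound 3 (0.25 log units; that floor lies within the scatter) from compound 2 cannot be separated from repeat scatter.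

Compound 4, `O=C1O[C@@H](CNC(=O)C(F)(F)F)CN1c1ccc(-n2cc(-c3ccccn3)cn2)c(F)c1`, is the next member of the series. The change from compound 3 is ((trifluoromethyl)carbonyl)amino in place of (thiophen-2-yl)sulfanyl on a saturated chain carbon bound to a saturated ring carbon. Among the compounds with values here, no measured step replaces the (thiophen-2-yl)sulfanyl with an amide, so there is no direct precedent. Within the data shown here, the steps that bear on it are a 2.3-fold higher number from compound 1 to compound 2 (0.35 log units; beyond the scatter) and an at least 4.0-fold higher number from compound 1 to compound 3 (0.60 log units; beyond the scatter): both run toward higher numbers once the 4-ethylpiperazin-1-yl leaves, and compound 2 and compound 3, which carry no such group, sit within scatter of each other. The expected step is therefore a number no higher from compound 3 to compound 4 (the limit leaves the size open), with no movement beyond the scatter, and a fair chance that the read-out is again a limit.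

Compound 4 is estimated at 400 ug/mL, with a range of 150 ug/mL to 800 ug/mL.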

Compound 4, half-maximal inhibitory concentration: > 400 ug/mL
Compound 4 ended at the assay's limit; the forecaster's own chance of this, stated with the estimate: 60%; the middle value lies on the limit itself.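

In this assay compound 4 gives > 400 ug/mL, a limit and not a number, so the place on a saturated chain carbon bound to a saturated ring carbon now holds a second group, this one with no ring and no sulfur, that ends at the limit: the limit of > 400 ug/mL in this assay, at which 2 of the 4 values shown sit. Within the data shown here, the (thiophen-2-yl)sulfanyl is thus not the only group that reaches this limit, and a nitrogen at the point of attachment does not by itself go with a low number, since ((trifluoromethyl)carbonyl)amino also joins through nitrogen and gives an at least 4.0-fold higher number from compound 1 to compound 4 (0.60 log units; beyond the scatter). Against the ester-bearing piperidine the result is less clear, with an at least 1.7-fold higher number from compound 2 to compound 4 (0.25 log units; that floor lies within the scatter), and the step between the two limited compounds, compound 3 and compound 4, cannot be read.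

On these data alone, how far compound 3 and compound 4 lie beyond the limit, and whether they differ at all, stays open. Also open, as far as these compounds go, is whether a simple acetamide, a free primary amine or a carboxylic acid in place of the trifluoroacetamide gives a measurable number on the same core.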